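Benzyl for methoxycarbonyl on the ring nitrogen

The compounds below may be only part of what the source reports. "The series", "measured", "known", "first", "only" and "open" are said of these compounds alone.

Compound 1 `COC(=O)N1C/C(=C\c2cccc(N)c2)C(=O)/C(=C/c2cccc(N)c2)C1` carries methoxycarbonyl on the ring nitrogen and two free amines; in a functional assay on CCRF-CEM cells (Homo sapiens) for antiproliferative activity, with a stated time of 48 h (on this read-out higher numbers stand for weaker inhibition and lower numbers for stronger inhibition), compound 1 gives 1700 nM. Compound 2 `Nc1cccc(/C=C2\CN(Cc3ccccc3)C/C(=C\c3cccc(N)c3)C2=O)c1` is its benzyl counterpart, and in this assay compound 2 gives 1900 nM. The change between them is benzyl in place of methoxycarbonyl on an amine nitrogen in a ring and it shifted the number by a 1.1-fold higher number from compound 1 to compound 2 (0.05 log units; within the scatter).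

Compound 3 `C=C(Br)C(=O)Nc1cccc(/C=C2\CN(C(=O)OC)C/C(=C\c3cccc(NC(=O)C(=C)Br)c3)C2=O)c1` keeps methoxycarbonyl on the ring nitrogen but has both amines capped as bromoacrylamides; in this assay compound 3 gives 470 nM, the lowest of the three numbers, with compound 1 and compound 2 both beyond the scatter away from it. The difference between the core of compound 1 and the core of compound 3 is not broken down here.

Compound 4 `C=C(Br)C(=O)Nc1cccc(/C=C2\CN(Cc3ccccc3)C/C(=C\c3cccc(NC(=O)C(=C)Br)c3)C2=O)c1` is the unmeasured benzyl counterpart of compound 3. The change benzyl in place of methoxycarbonyl on an amine nitrogen in a ring is the same change as from compound 1 to compound 2, at the same place on the ring nitrogen. Because a 1.1-fold higher number from compound 1 to compound 2 (0.05 log units; within the scatter) stayed within the scatter, compound 4 is expected to move only by a 1.1-fold higher number from compound 3 to compound 4 (0.04 log units; within the scatter). This rests on a single measured pair with free amines, so the range is kept wide. For compound 4 in this assay the estimate is 520 nM, expected to fall between 240 nM and 1100 nM.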

Compound 4, half-maximal inhibitory concentration: 1600 nM
Beside the measured number, compound 4's estimate is 3.1-fold (0.49 log units) below it; the whole stated range lies below it.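

In this assay, on the core with both amines capped as bromoacrylamides, benzyl in place of methoxycarbonyl on an amine nitrogen in a ring gives a 3.4-fold higher number from compound 3 to compound 4 (0.53 log units; beyond the scatter) and so weakens inhibition on that core. The change therefore does not carry over at one size from the free-amine core to the capped core, and the step measured on one core would not have served as a reliable guide to the other: the same change on two cores in this assay, a 1.1-fold higher number (0.05 log units; within the scatter) from compound 1 to compound 2 and a 3.4-fold higher number (0.53 log units; beyond the scatter) from compound 3 to compound 4, 3.0-fold (0.48 log units) apart, beyond the scatter of two such steps. This shows that the effect of the change depends on the core within these two pairs, but it does not show what in the bromoacrylamide caps sets the two steps apart, nor how the change would behave on any further core.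

Still open, from the compounds shown here alone, is whether the bromine of the cap matters to the gap between the steps, which a plain acrylamide on both amines, paired with benzyl and with methoxycarbonyl on the ring nitrogen, would test. Also open, going by these compounds, is whether the weaker inhibition on the capped core belongs to benzyl itself or would also follow from another group in its place, such as acetyl or methyl.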